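Ortho-alkoxy on the phenylpiperazine: methoxy on the longer chain

The compounds below may be only part of what the source reports. "The series", "measured", "known", "first", "only" and "open" are said of these compounds alone.

Three analogues sharing one core have been measured. Compound 1 `Cc1ccc(-c2nn(CCN3CCN(c4ccccc4)CC3)c(=O)c3ccccc23)cc1` gives 25.3 nM in an assay on Cerebral cortex for displacement of a labelled ligand from Adrenergic receptor alpha-1 (Rattus norvegicus); on this read-out higher numbers stand for weaker inhibition and lower numbers for stronger inhibition. Compound 2 `CCOc1ccccc1N1CCN(CCn2nc(-c3ccc(C)cc3)c3ccccc3c2=O)CC1` gives 3.9 nM in this assay. Compound 3 `Cc1ccc(-c2nn(CCCCN3CCN(c4ccccc4)CC3)c(=O)c3ccccc23)cc1` gives 23.9 nM in this assay. Compound 3 holds the second highest of the three numbers: against compound 1 it sits within the scatter, against compound 2 it is separated by a gap beyond the scatter.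

The unmeasured compound 4 `COc1ccccc1N1CCN(CCCCn2nc(-c3ccc(C)cc3)c3ccccc3c2=O)CC1` differs from compound 3 by methoxy in place of hydrogen on an aromatic carbon. For the measured compounds named here, the one measured step that bears on this is a 6.5-fold lower number from compound 1 to compound 2 (0.81 log units; beyond the scatter), where ethoxy entered at the same kind of position on the shorter two-carbon chain. The two chain lengths, compound 1 and compound 3, sit within the scatter of one another, so the chain length itself does not appear to move the number. Methoxy is smaller than ethoxy, and whether that matters here is unknown; the single step available points the same way.

For compound 4 the number in this assay is therefore expected to fall below that of compound 3 by roughly a 4.3-fold lower number from compound 3 to compound 4 (0.64 log units; beyond the scatter). Compound 4 is estimated at 5.5 nM, with a range of 2.2 nM to 14 nM.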

Compound 4, inhibition constant: 2.6 nM
Beside the measured number, compound 4's estimate is 2.1-fold (0.33 log units) above it; the range from low to high includes it.
By their numbers in this assay, from the lowest: compounds 4 and 2 (each within the scatter of the next); then compounds 3 and 1 (each within the scatter of the next).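

Methoxy in place of hydrogen, on an aromatic carbon ortho to a large group, gives a 9.2-fold lower number from compound 3 to compound 4 (0.96 log units; beyond the scatter) in this assay, so the lowering at this position no longer rests on ethoxy and the shorter chain alone. With a 6.5-fold lower number from compound 1 to compound 2 (0.81 log units; beyond the scatter) on the shorter chain, the position now carries two steps in the same direction, both beyond the scatter, one on each chain length and each with a different alkoxy group, and no compound shown goes against this pattern. The chain length that left the number within the scatter between the two unsubstituted phenyl compounds does not stop the change from phenyl to 2-methoxyphenyl from acting, but nothing shown gives a measured reason for either step.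

Each alkoxy group appears here on one chain length only, so methoxy and ethoxy cannot be set apart, and any difference between the two steps cannot be assigned to the group or to the chain. Also open, on these data alone, is what a hydroxyl group or an amine at this same place would do to the number, and whether the lowering persists on a longer chain.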